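Compound 4: cyano in place of methyl

A few compounds are considered here, and "the series" means these few. Any claim that something is new, unique, unknown or untested is made for them only; others in the source may bear on it.

In an ADME assay on HEK293 cells (Homo sapiens) for cytotoxicity, read by CellTiter-Glo, with a stated time of 72 h (a higher number here means that more compound is needed for the effect, a lower number that less compound is needed), compound 1 (`C[C@@H]1CC[C@H]2CC3C(=O)CC[C@@]31C2(C)C`) gives 26000 nM as its reading, compound 2 (`CC1=C2CC(C)(C)/C=C/C(=O)/C(C)=C\C3=C[C@H](C)C[C@]3(O2)[C@@]1(O)C(F)(F)F`) gives 26000 nM and compound 3 (`CC1=C2CC(C)(C)/C=C/C(=O)/C(C)=C\C3=C[C@H](C)C[C@]3(O2)[C@]1(C)O`) gives 26000 nM as well. Compound 3 therefore stands level with compounds 1 and 2 at the digits shown, and nothing in these numbers separates the three.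

The next structure is compound 4 (`CC1=C2CC(C)(C)/C=C/C(=O)/C(C)=C\C3=C[C@H](C)C[C@]3(O2)[C@@]1(O)C#N`), which differs from compound 3 as follows: cyano in place of methyl on a saturated ring carbon (in words, cyano in place of methyl on a saturated ring carbon). The shared core is otherwise unchanged.

For the measured compounds named here, only one measured step bears on this change. It is no change at the digits printed from compound 2 to compound 3 (within the scatter) for methyl in place of trifluoromethyl on a saturated ring carbon, the same carbon that changes here. Going by the values given here, no measured compound carries cyano, so the expectation rests on that single exchange and remains weakly supported. Expected in this assay is no change at the digits printed from compound 3 to compound 4 (within the scatter) and so no step beyond the scatter, in either direction. For compound 4 the expected value is 26000 nM with a range from 13000 nM to 45000 nM as the estimate.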

Compound 4, half-maximal effective concentration: 26000 nM
Beside the measured number, compound 4's estimate shows no gap at the digits printed, within the range that was stated.
By their numbers in this assay, from the lowest: compounds 1, 2, 3 and 4 (each within the scatter of the next).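

In this assay the saturated ring carbon has now carried three different groups, and the readings do not separate them: the exchange of methyl for cyano gives no change at the digits printed from compound 3 to compound 4 (within the scatter) and the exchange of trifluoromethyl for cyano gives no change at the digits printed from compound 2 to compound 4 (within the scatter) on the same carbon. Where the earlier compounds offered a single exchange at this position, the series now has a closed set of three compounds, and the flat reading extends to a group that brings a triple bond and a hydrogen-bond acceptor, neither of which methyl has. No supporting measurement is available to account for this flat result.

Whether the reading in this assay stays flat with an amine, a carboxylic acid or a longer alkyl chain on this carbon remains open, as all three groups shown here are small and uncharged. Also open, going by these compounds, is whether a change elsewhere on the shared core would produce a step beyond the scatter.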